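Swapping the tetralin ether for a biphenyl ether

The source may hold more compounds than are shown below. What is called first, only, known or untested is meant among the compounds shown, and "the series" means these compounds.

Measured so far:
compound 1 `CO[C@H]1O[C@H](COc2ccc3c(c2)CCCC3)[C@@H](O)[C@H](O)[C@H]1Oc1ccc(OC2CCCCC2)cc1` – 20000 nM
compound 2 `CO[C@@H]1O[C@H](COc2ccc3c(c2)CCCC3)[C@@H](O)[C@H](O)[C@H]1Oc1ccc(OC2CCCCC2)cc1` – "not determined" (no result reported)

In a functional assay on MDA-MB-231 cells (Homo sapiens) for cytotoxicity, read by MTT assay, with a stated time of 48 h (on this read-out higher numbers stand for an effect only at larger amounts of compound and lower numbers for an effect already at smaller amounts), compound 1 gives 20000 nM. Compound 2 `CO[C@@H]1O[C@H](COc2ccc3c(c2)CCCC3)[C@@H](O)[C@H](O)[C@H]1Oc1ccc(OC2CCCCC2)cc1` gives "not determined" (no result reported) in this assay, so there is no number for it; the two share everything except (the fact that compounds 1 and 2 differ only in the configuration as drawn). Compound 3 `CO[C@@H]1O[C@H](COc2ccc(-c3ccccc3)cc2)[C@@H](O)[C@H](O)[C@H]1Oc1ccc(OC2CCCCC2)cc1` is next, differing from compound 2 by 4-phenylphenyl in place of 1,2,3,4-tetrahydronaphthalen-6-yl on an oxygen on a saturated carbon. Going by the values given here, with no measured step to lean on, the change is expected to shift the read-out in this assay by no more than the usual scatter, in either direction. Compound 3 is therefore estimated at 20000 nM, within 5000 nM to 80000 nM.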

Compound 3, half-maximal effective concentration: 36000 nM
Compound 3: middle estimate off by 1.8-fold (0.26 log units), on the low side; the range from low to high includes it.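

Going by these compounds alone, compound 2 has no number in this assay, and compound 1 differs from compound 3 in more than one place, so no step to compound 3 can be read. From the compounds shown here alone, what swapping 1,2,3,4-tetrahydronaphthalen-6-yl for 4-phenylphenyl does to the read-out stays open. Nothing known here bears on the result for compound 3.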